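This account rests on a few compounds, and the source may have more. Where it says the series, first, only, none or still open, it means among the compounds named here.

Compound 3 `Cc1ccc(C(=O)Nc2cc(-c3ccccc3)nn2-c2ccccc2)cn1` stands second highest of the three numbers in a functional assay on cells for positive allosteric modulation of metabotropic glutamate receptor 5 (Rattus norvegicus), read by calcium flux; on this read-out higher numbers stand for an effect only at larger amounts of compound and lower numbers for an effect already at smaller amounts: compound 3 gives 280 nM, while compound 1 `COc1ccc(C(=O)Nc2cc(-c3ccccc3)nn2-c2ccccc2)cc1` gives 54 nM and compound 2 `COc1cc(OC)cc(C(=O)Nc2cc(-c3ccccc3)nn2-c2ccccc2)c1` gives 2040 nM. Compound 4 `O=C(Nc1cc(-c2ccccc2)nn1-c1ccccc1)C1CCCCC1` differs from compound 3 by cyclohexyl in place of 6-methylpyridin-3-yl on a carbonyl carbon. For the measured compounds named here, no measured step exchanges an aromatic ring for a saturated one; the steps seen so far only change which ring sits on the carbonyl carbon, and they ran a 38-fold higher number from compound 1 to compound 2 (1.58 log units; beyond the scatter) and a 5.2-fold higher number from compound 1 to compound 3 (0.71 log units; beyond the scatter), with a 7.3-fold lower number from compound 2 to compound 3 (0.86 log units; beyond the scatter) between the two weaker compounds. Going by the values given here, this position clearly moves this assay, but the direction for a cyclohexyl ring has no direct precedent. Compound 4 is therefore expected to give a higher number, a step of a 3.2-fold higher number from compound 3 to compound 4 (0.51 log units; beyond the scatter). The estimate for compound 4 is 900 nM, with a range from 150 nM to 6000 nM.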

Compound 4, half-maximal effective concentration: > 10000 nM
Compound 4: no number, only a limit; the forecaster's own chance of this, stated with the estimate: 15%; at least 11-fold (1.04 log units) between middle value and limit.
By their numbers in this assay, from the lowest: compound 1; then compound 3; then compound 2. At a limit, above all of these: compound 4.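

Compound 4 gives no number in this assay, only a limit: the limit of > 10000 nM in this assay, at which 1 of the 4 values shown sits. The cyclohexyl ring on the carbonyl carbon comes with an at least 35-fold higher number from compound 3 to compound 4 (1.55 log units; beyond the scatter), with an at least 4.9-fold higher number from compound 2 to compound 4 (0.69 log units; beyond the scatter) and with an at least 180-fold higher number from compound 1 to compound 4 (2.26 log units; beyond the scatter). The earlier compounds varied only aromatic rings at this place, and among these four compounds the three with an aromatic ring give a measured number while the one with a saturated ring does not.

Going by these compounds, how far compound 4 lies past its limit stays open. Also open, on these data alone, is whether this holds for cyclohexyl alone or also for a piperidin-4-yl ring, a tetrahydropyran-4-yl ring or an open butyl chain on the same carbonyl carbon.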